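The source may hold more compounds than are shown below. What is called first, only, known or untested is meant among the compounds shown, and "the series" means these compounds.

In a functional assay on SMMC-7721 cells (Homo sapiens) for cytotoxicity, read by MTT assay, with a stated time of 72 h (on this read-out higher numbers stand for weaker inhibition and lower numbers for stronger inhibition), compound 2 `COc1cccc(C=C2C(=O)N(c3ccc(Cl)cc3)N(c3ccc(Cl)cc3)C2=O)c1O` gives 64900 nM. Compound 1 `CCC(C)=C1C(=O)N(c2ccc(Cl)cc2)N(c2ccc(Cl)cc2)C1=O` gives 49200 nM, and compound 3 `CC(=C1C(=O)N(c2ccc(Cl)cc2)N(c2ccc(Cl)cc2)C1=O)c1ccc(O)cc1` gives 57000 nM. All three values lie within the scatter of one another. Compound 4 `O=C1C(=Cc2ccc(F)cc2F)C(=O)N(c2ccc(Cl)cc2)N1c1ccc(Cl)cc1` keeps the shared core of compound 2 and changes one group: 2,4-difluorophenyl in place of 2-hydroxy-3-methoxyphenyl on a double-bonded chain carbon bound to a double-bonded ring carbon. For the measured compounds named here, no measured compound carries 2,4-difluorophenyl, so the evidence is indirect. Going by the values given here, the one measured step on a double-bonded chain carbon, where 4-hydroxyphenyl replaces ethyl, is a 1.2-fold higher number from compound 1 to compound 3 (0.06 log units; within the scatter), and that exchange of quite different groups stays within the scatter. No clear shift in either direction is therefore expected, and the expected step is a 1.4-fold lower number from compound 2 to compound 4 (0.13 log units; within the scatter). The estimate for compound 4 is 48000 nM, with an expected range from 20000 nM to 100000 nM.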

Compound 4, half-maximal inhibitory concentration: 35800 nM
The estimate for compound 4 lay 1.3-fold (0.13 log units) above the measured number; measured number inside the range.
By their numbers in this assay, from the lowest: compounds 4, 1, 3 and 2 (each within the scatter of the next).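

With 2,4-difluorophenyl in place of 2-hydroxy-3-methoxyphenyl on a double-bonded chain carbon bound to a double-bonded ring carbon, the result is a 1.8-fold lower number from compound 2 to compound 4 (0.26 log units; within the scatter) in this series. The entering ring has no hydrogen-bond donor or acceptor, so an aromatic ring at this position can lack both without the number moving beyond the scatter. No measurement here accounts for the size of this step. Still open, going by these compounds, is whether an amine, a carboxylic acid or a longer chain on this carbon would move the number beyond the scatter.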